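This account rests on a few compounds, and the source may have more. Where it says the series, first, only, none or still open, it means among the compounds named here.

Measured so far in a functional assay on HT-22 cells (Mus musculus), read by MTT assay, with a stated time of 24 h; on this read-out higher numbers stand for an effect only at larger amounts of compound and lower numbers for an effect already at smaller amounts:
- compound 1 `Cc1cc(O)c(C(=O)/C=C/c2ccc(O)c(O)c2)cc1C`: 50 nM
- compound 2 `COc1ccc(/C=C/C(=O)c2cc(C)c(C)cc2O)cc1OCc1ccccc1`: "not active" (no number reported)

Compound 2 has no single number to stand on: it is reported as "not active" (no number reported), while compound 1 gives 50 nM. Among the compounds with values here, no measured pair differs in one place only, so no step size can be carried over.

Next is compound 3 `COc1ccc(/C=C/C(=O)c2cc(C)c(C)cc2O)cc1O`, with the change (hydrogen in place of benzyl on an oxygen on an aromatic ring). This is benzyloxy to hydroxy, a hydrogen in place of benzyl on an oxygen on an aromatic ring. A move from no reported effect towards a measurable one is expected in this assay, but its size cannot be stated without a number for compound 2. The expectation rests on compound 1, which also has a free hydroxy in that region and gives 50 nM. A result of not active remains possible.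

For compound 3 the estimated value is 300 nM, with an expected range of 50 nM to 3000 nM.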

Compound 3, half-maximal effective concentration: 200 nM
Estimate against measurement, compound 3: 1.5-fold (0.18 log units) above, within the range that was stated.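

In this assay, hydrogen in place of benzyl on the oxygen takes compound 2 from "not active" (no number reported) to compound 3 (200 nM), so a measurable effect is seen with the hydroxy, although this step cannot be read as a size. The series also now has its first readable step at this kind of place: with methyl in place of hydrogen on an oxygen on an aromatic ring, there is a 4.0-fold higher number from compound 1 to compound 3 (0.60 log units; beyond the scatter) in the same assay, so a free hydroxy there is not needed for a nanomolar effect, but the change is not neutral. Nothing measured here accounts for either change. Open, on these data alone, is how the read-out runs for ethyl or propyl on that oxygen, between methyl and benzyl. Also open, as far as these compounds go, is whether an amine in place of that oxygen keeps the effect.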